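Nitro for Methoxy: Expected Tolerance of Compound 4

The source may report more compounds than this note shows. Statements on the series, on what has been measured and on what is new or still open speak of the compounds shown alone.

Compound 1 `COc1ccc(CSc2nc(Cc3cc(C(F)(F)F)cc(C(F)(F)F)c3)c(C)c(=O)[nH]2)cc1` and compound 2 `Cc1c(Cc2cc(C(F)(F)F)cc(C(F)(F)F)c2)nc(SCc2ccc([N+](=O)[O-])cc2)[nH]c1=O` share a core and differ by nitro in place of methoxy on an aromatic carbon. In an ADME assay on MT4 cells (Homo sapiens) for cytotoxicity, read by MTT assay (a higher number here means that more compound is tolerated, a lower number that less compound is tolerated), compound 1 reaches only the limit > 256000 nM. Compound 2 likewise gives only the limit > 248000 nM. The step that the two limits leave unreadable from compound 1 to compound 2 therefore cannot be sized, the two values being the limits the limit of > 248000 nM in this assay, at which 1 of the 3 values shown sits, and (the limit of > 256000 nM in this assay, at which 1 of the 3 values shown sits). Compound 3 `CCc1c(Cc2cccc(Br)c2)nc(SCc2ccc(OC)cc2)[nH]c1=O` carries a different core; how it differs from compound 1 is not broken down here. In this assay, within the data shown here, compound 3 gives 201000 nM, the only number among the three. Compound 4 `CCc1c(Cc2cccc(Br)c2)nc(SCc2ccc([N+](=O)[O-])cc2)[nH]c1=O` differs from compound 3 by nitro in place of methoxy on an aromatic carbon, the same change in the same place. Because a step that the two limits leave unreadable from compound 1 to compound 2 gives no readable size, the expected step of a 1.1-fold lower number from compound 3 to compound 4 (0.02 log units; within the scatter) is small. Compound 4 is accordingly estimated at 190000 nM, between 90000 nM and 300000 nM.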

Compound 4, half-maximal cytotoxic concentration: 187000 nM
Beside the measured number, compound 4's estimate is 1.0-fold (0.01 log units) above it, within the range that was stated.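

On the core of compound 3, nitro in place of methoxy on an aromatic carbon gives a 1.1-fold lower number from compound 3 to compound 4 (0.03 log units; within the scatter) in this assay, so the two compounds cannot be told apart here. On the core of compound 1 the same change cannot be sized, as compound 1 and compound 2 each give only a limit of the assay. The series therefore shows one readable step on one core, and it does not show that the change carries over from one core to the other with the same size.

Still open, going by these compounds, is how this assay reads when an amine or a carboxylic acid stands in place of the methoxy or nitro. Also open, on these data alone, is what a longer chain in place of the ethyl of compound 3 would give.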